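Swapping the chlorinated ring for methyl: a toxicity forecast

A few compounds are considered here, and "the series" means these few. Any claim that something is new, unique, unknown or untested is made for them only; others in the source may bear on it.

Of the compounds shown here, three have been tested in an ADME assay on HEp-2 cells (Homo sapiens) for cytotoxicity, read by MTT assay, with a stated time of 3 days; on this read-out lower numbers stand for higher toxicity in this test and higher numbers for lower toxicity in this test. Compound 1 `CC[C@@H](CCn1cncn1)c1ccc(Cl)cc1` gives 55.1 ug/mL. Compound 2 `Clc1ccc([C@@H](CCn2cncn2)Cc2ccccc2)cc1` gives 25.9 ug/mL, and compound 3 `Clc1ccc([C@H](CCn2cncn2)Cc2ccccc2)cc1` gives 25.7 ug/mL. Compound 3 shows the lowest number of the three, but its neighbour compound 2 sits so close that the two cannot be told apart: a 1.0-fold lower number from compound 2 to compound 3 (0.00 log units; within the scatter), which fits with the fact that compounds 2 and 3 differ only in the configuration as drawn. Going by the values given here, the only step beyond the scatter is a 2.1-fold lower number from compound 1 to compound 3 (0.33 log units; beyond the scatter), where an aromatic ring entered the chain.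

Compound 4 `C[C@H](CCn1cncn1)Cc1ccccc1` has not been measured. It differs from compound 3 in one place: methyl in place of 4-chlorophenyl on a saturated chain carbon bound to two saturated chain carbons. Among the compounds with values here, no measured step removes an aromatic ring from the core, so the closest guide is the step from compound 1 to compound 3, read in reverse: taking an aromatic ring away would be expected to raise the number in this assay by a modest amount. For compound 4 the estimated result is 60 ug/mL, within a range of 30 ug/mL to 120 ug/mL. This estimate means a step of a 2.3-fold higher number from compound 3 to compound 4 (0.37 log units; beyond the scatter), expected to fall just beyond the scatter.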

Compound 4, half-maximal cytotoxic concentration: 144 ug/mL
Estimate against measurement, compound 4: 2.4-fold (0.38 log units) below; the measured number lies above the stated range.
By their numbers in this assay, from the lowest: compounds 3 and 2 (each within the scatter of the next); then compound 1; then compound 4.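

Putting methyl in place of 4-chlorophenyl on a saturated chain carbon bound to two saturated chain carbons brings, in this assay, a 5.6-fold higher number from compound 3 to compound 4 (0.75 log units; beyond the scatter). Going by these compounds alone, this is the first measured step that takes an aromatic ring off this carbon, and it shows that the group held here matters for this read-out, with the higher number standing for lower toxicity in this test. The change removes a ring and a chlorine together, and nothing at hand explains the rise.

The compounds shown do not separate the part played by the chlorine from that of the ring it sits on. They also leave open how this carbon would read with an amine, a carboxylic acid or a longer chain in place of methyl.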